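The source may report more compounds than this note shows. Statements on the series, on what has been measured and on what is new or still open speak of the compounds shown alone.

Measured compounds:
Compound 1, `COC(=O)c1ccc2ccc(C(=O)N(C)C)c-2cc1`, 7.4 10^-6 cm/s in an ADME assay for permeability, using PAMPA, at pH 7.4; on this read-out higher numbers stand for higher permeability and lower numbers for lower permeability.
Compound 2, `CN(C)C(=O)c1ccc2cccccc1-2`, 7.6 10^-6 cm/s in this assay.
Compound 3, `CN(C)C(=O)c1cn(C)c2ccccc12`, 6.7 10^-6 cm/s in this assay.

Compound 2 and compound 1 differ by one change, (methoxycarbonyl in place of hydrogen on an aromatic carbon), and that change gave a 1.0-fold lower number from compound 2 to compound 1 (0.01 log units; within the scatter). Compound 4, `COC(=O)c1ccc2c(C(=O)N(C)C)cn(C)c2c1`, has not yet been measured in this assay; it differs from compound 3 by the same kind of change, (methoxycarbonyl in place of hydrogen on an aromatic carbon), but the surroundings differ: in compound 1 the group sits on a seven-membered aromatic ring of carbon only, whereas in compound 4 it sits on a six-membered aromatic ring of carbon only, meta to a fused ring and para to a fused ring. The difference between the two cores of compound 2 and compound 3 is not broken down here; their values lie within the scatter of each other.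

Because the earlier change gave a 1.0-fold lower number from compound 2 to compound 1 (0.01 log units; within the scatter), compound 4 is expected to show a step of about a 1.0-fold lower number from compound 3 to compound 4 (0.01 log units; within the scatter) in this assay. The estimate for compound 4 is 6.5 10^-6 cm/s, expected to fall between 4 10^-6 cm/s and 10.5 10^-6 cm/s.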

Compound 4, apparent permeability in the ADME assay: 4.2 10^-6 cm/s
Compound 4: middle estimate off by 1.5-fold (0.19 log units), on the high side; measured number inside the range.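

In the ADME assay, methoxycarbonyl in place of hydrogen on an aromatic carbon gave a 1.6-fold lower number from compound 3 to compound 4 (0.20 log units; within the scatter), and the two steps for this change agree: the same change on two cores in the ADME assay, a 1.0-fold lower number (0.01 log units; within the scatter) from compound 2 to compound 1 and a 1.6-fold lower number (0.20 log units; within the scatter) from compound 3 to compound 4, 1.6-fold (0.19 log units) apart, within the scatter of two such steps The change therefore carried from one core to the other without a step beyond the scatter, but two cores cannot show that this would hold on other cores or at other places on the ring. In a physicochemical assay for solubility, with a stated time of 24 h, at pH 6.8 (a higher number here means a more soluble compound, a lower number a less soluble compound), compound 3 gives > 51 ug/mL, a limit of the assay and not a number. In the physicochemical assay compound 4 gives 49 ug/mL, but the step to compound 4 cannot be read there: the limit of > 51 ug/mL in the physicochemical assay, at which 1 of the 2 values shown sits.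

The compounds shown leave open whether a carboxylic acid or an amine in place of methoxycarbonyl would also stay within the scatter in the ADME assay.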